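This account rests on a few compounds, and the source may have more. Where it says the series, first, only, none or still open, it means among the compounds named here.

In a functional assay on HT-29 cells (Homo sapiens) for inhibition, with a stated time of 72 h (on this read-out lower numbers stand for stronger inhibition and higher numbers for weaker inhibition), compound 3 `COc1ccc(S(=O)(=O)N2CCc3cccc(-c4ccccc4)c32)cc1` gives 96.5 nM, within the scatter of both compound 1 `COc1ccc(S(=O)(=O)N2CCc3cccc(-c4ccc(F)nc4)c32)cc1` at 109 nM and compound 2 `COc1ccc(S(=O)(=O)N2CCc3cccc(-c4ccco4)c32)cc1` at 62.5 nM. The unmeasured compound 4 `COc1ccc(S(=O)(=O)N2CCc3cccc(-c4cccs4)c32)cc1` has thiophen-2-yl in place of phenyl on an aromatic carbon. Three measured exchanges on that aromatic carbon bear on this change: furan-2-yl to phenyl gives a 1.5-fold higher number from compound 2 to compound 3 (0.19 log units; within the scatter), 6-fluoropyridin-3-yl to phenyl gives a 1.1-fold lower number from compound 1 to compound 3 (0.05 log units; within the scatter), and 6-fluoropyridin-3-yl to furan-2-yl gives a 1.7-fold lower number from compound 1 to compound 2 (0.24 log units; within the scatter). None leaves the scatter, so no step beyond the scatter, and no firm direction, is expected in this assay. The expected step is a 1.2-fold lower number from compound 3 to compound 4 (0.08 log units; within the scatter). Compound 4 is estimated at 80 nM, with an expected range of 38 nM to 170 nM.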

Compound 4, half-maximal inhibitory concentration: 200 nM
Compound 4: the middle estimate sits 2.5-fold (0.40 log units) below what was measured; measured number outside the range, above it.
By their numbers in this assay, from the lowest: compounds 2, 3, 1 and 4 (each within the scatter of the next, the first and the last beyond it).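

In this assay this aromatic carbon now shows steps beyond the scatter, though modest ones: a 2.1-fold higher number from compound 3 to compound 4 (0.32 log units; beyond the scatter) and a 3.2-fold higher number from compound 2 to compound 4 (0.51 log units; beyond the scatter) stand against the earlier exchanges, none of which left the scatter, while a 1.8-fold higher number from compound 1 to compound 4 (0.26 log units; within the scatter) stays within it. Thiophen-2-yl and furan-2-yl are thus told apart, so a five-membered aromatic ring alone does not fix the number here. No measurement at hand accounts for these steps. On these data alone, whether an amine or a carboxylic acid on this carbon would shift the number further remains open, as does whether the thiophen-2-yl step recurs on another core.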